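The source may hold more compounds than are shown below. What is called first, only, known or untested is meant among the compounds shown, and "the series" means these compounds.

Three of these compounds share one core and differ only in the group attached to the carbonyl carbon whose other neighbour is the amide-type nitrogen in the ring. Compound 1 `CC(C)(C)OC(=O)N1CCC(CN(Cc2ccc(Cl)cc2)Cc2ccc([N+](=O)[O-])s2)C1` carries tert-butyl on the oxygen there, and in a functional assay on HEK293 cells for agonist activity at nuclear receptor subfamily 1 group D member 1 (Homo sapiens), read by a luciferase reporter, with a stated time of 24 h (on this read-out higher numbers stand for an effect only at larger amounts of compound and lower numbers for an effect already at smaller amounts), compound 1 gives 1800 nM. Compound 2 `O=C(Oc1ccccc1)N1CCC(CN(Cc2ccc(Cl)cc2)Cc2ccc([N+](=O)[O-])s2)C1` carries phenyl on that oxygen, and in this assay compound 2 gives "not determined" (no result reported), so no number is available for it. Compound 3 `C=CCOC(=O)N1CCC(CN(Cc2ccc(Cl)cc2)Cc2ccc([N+](=O)[O-])s2)C1` carries allyl, and in this assay compound 3 gives 670 nM. Within the data shown here, of the two numbers available, compound 3 has the lower one, and the single measured step, a 2.7-fold lower number from compound 1 to compound 3 (0.43 log units; beyond the scatter), separates it from compound 1.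

Compound 4 `O=C(Nc1ccc([N+](=O)[O-])cc1)N1CCC(CN(Cc2ccc(Cl)cc2)Cc2ccc([N+](=O)[O-])s2)C1` goes further: (4-nitrophenyl)amino in place of allyloxy on a carbonyl carbon. Among the measured compounds shown here, no measured step bears directly on a change of this kind. For the measured compounds named here, the one step in hand, a 2.7-fold lower number from compound 1 to compound 3 (0.43 log units; beyond the scatter), exchanged one chain for another on the oxygen and stayed modest, whereas compound 4 removes that oxygen altogether and brings in an aromatic ring with a hydrogen-bond donor and two acceptors. With nothing closer to lean on, the step of a 1.2-fold higher number from compound 3 to compound 4 (0.08 log units; within the scatter) is expected to be small, though the uncertainty around it is wide. Compound 4 is therefore estimated at 800 nM, within a range of 200 nM to 3000 nM.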

Compound 4, half-maximal effective concentration: 400 nM
Compound 4: middle estimate off by 2.0-fold (0.30 log units), on the high side; measured number inside the range.
By their numbers in this assay, from the lowest: compounds 4 and 3 (each within the scatter of the next); then compound 1.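

Replacing allyloxy on this carbonyl carbon, a group of 4 heavy atoms, with (4-nitrophenyl)amino, a group of 10 heavy atoms with an aromatic ring and a hydrogen-bond donor, gives a 1.7-fold lower number from compound 3 to compound 4 (0.22 log units; within the scatter) and so leaves the two compounds within the usual scatter in this assay, which shows that this place accepts much more than an exchange of one small chain on the oxygen. Set against tert-butoxy, the same group gives a 4.5-fold lower number from compound 1 to compound 4 (0.65 log units; beyond the scatter) and shows that, among these compounds, the oxygen on the carbonyl carbon is not required for a number in this range. No supporting measurement is available to explain these results.

The compounds shown leave open whether the nitro group on the new ring matters, since neither plain phenylamino nor 4-methoxyphenylamino appears among them, and compound 2 has no number to show how phenyl on the oxygen compares. They also do not tell how a simple alkylamino group such as ethylamino, or a plain carbon chain directly on the carbonyl carbon, would read at this place.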